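This account rests on a few compounds, and the source may have more. Where it says the series, first, only, none or still open, it means among the compounds named here.

Working notes on the series. In a functional assay on DU-145 cells (Homo sapiens) for inhibition, read by trypan blue exclusion, with a stated time of 96 h (a higher number here means a weaker inhibitor of growth, a lower number a stronger inhibitor of growth), compound 1 (`O=C(/C(=C\c1ccc(Cl)cc1Cl)S(=O)(=O)c1ccc(Br)cc1)c1ccc(Cl)cc1`) gives 50000 nM and compound 3 (`O=C(/C(=C\c1ccccc1F)S(=O)(=O)c1ccc(Br)cc1)c1ccc(Cl)cc1`) gives 25000 nM. Compound 2 (`Cc1ccc(S/C(=C/c2ccc(N(C)C)cc2)C(=O)c2ccc(Cl)cc2)cc1`) is reported only as a limit, > 100000 nM. Within the data shown here, compound 3 therefore stands level, within the scatter, with compound 1, the only other compound with a number.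

Compound 4 (`CN(C)c1ccc(/C=C(\C(=O)c2ccc(Cl)cc2)S(=O)(=O)c2ccc(Br)cc2)cc1`) differs from compound 3 by one exchange: 4-(dimethylamino)phenyl in place of 2-fluorophenyl on a double-bonded chain carbon bound to a double-bonded chain carbon. It has 4-(dimethylamino)phenyl in place of 2-fluorophenyl on a double-bonded chain carbon bound to a double-bonded chain carbon. Among the measured compounds shown here, the only measured change at this place is a 2.0-fold lower number from compound 1 to compound 3 (0.30 log units; within the scatter), which replaces 2,4-dichlorophenyl with 2-fluorophenyl. For the measured compounds named here, that step sets a modest expectation, since the one exchange measured here did not move the number beyond the scatter. Going by the values given here, compound 2 also carries 4-(dimethylamino)phenyl, but it differs from compound 4 elsewhere as well, so it gives no clean step and only a weak lean toward a higher number in this assay. Among the compounds with values here, no step clearly beyond the scatter is expected, and compound 4 could also be returned only as a limit.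

The expected step is a 1.6-fold higher number from compound 3 to compound 4 (0.20 log units; within the scatter). For compound 4 the estimated value is 40000 nM, with an expected range of 15000 nM to 100000 nM.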

Compound 4, concentration for 50% growth inhibition: > 100000 nM
Compound 4 gave a limit, no number; the forecaster's own chance of this, stated with the estimate: 25%; middle value at least 2.5-fold (0.39 log units) from the limit.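

In this assay, among these compounds, the place on a double-bonded chain carbon bound to a double-bonded chain carbon now shows that it can respond to an exchange: 4-(dimethylamino)phenyl in place of 2-fluorophenyl gives an at least 4.0-fold higher number from compound 3 to compound 4 (0.60 log units; beyond the scatter), whereas the one earlier step measured here stayed within the scatter. With 4-(dimethylamino)phenyl in place of 2,4-dichlorophenyl, the result is an at least 2.0-fold higher number from compound 1 to compound 4 (0.30 log units; that floor lies within the scatter), which points the same way, although its floor alone establishes no difference. Compound 4 is reported only as a limit, not a number, and compound 2 is reported at the same limit: the limit of > 100000 nM in this assay, at which 2 of the 4 values shown sit.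

On these data alone, the step between compound 2 and compound 4, where (4-bromophenyl)sulfonyl replaces (4-methylphenyl)sulfanyl, cannot be read from two limits, so the contribution of that exchange remains open. The compounds shown also do not separate the dimethylamino group from the rest of the 4-(dimethylamino)phenyl group, and a 4-methoxyphenyl or 4-aminophenyl group at the same place would show whether the higher number is specific to the dimethylamino group.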